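Removing one sugar hydroxy from a triazole-linked compound

The source may hold more compounds than are shown below. What is called first, only, known or untested is meant among the compounds shown, and "the series" means these compounds.

In a functional assay on A-375 cells (Homo sapiens) for cytotoxicity, read by MTT assay, with a stated time of 72 h (on this read-out lower numbers stand for stronger inhibition and higher numbers for weaker inhibition), compound 1 `CN(C)CCCCCn1c2c(c3ccccc31)C(=O)c1c[n+]([O-])c3ccccc3c1C2=O` gives 560 nM and compound 2 `O=C1c2c[n+]([O-])c3ccccc3c2C(=O)c2c1c1ccccc1n2Cc1cn([C@H]2O[C@H](CO)[C@@H](O)[C@H]2O)nn1` gives 340 nM on the same test. These two numbers lie within the usual scatter of each other, so compound 2 cannot be ranked apart from compound 1. Compound 3 `O=C1c2c[n+]([O-])c3ccccc3c2C(=O)c2c1c1ccccc1n2Cc1cn([C@@H]2C[C@H](O)[C@@H](CO)O2)nn1` keeps the shared core and differs from compound 2 in one place (hydrogen in place of hydroxy on a saturated ring carbon). It has hydrogen in place of hydroxy on a saturated ring carbon, so 3,4-dihydroxy-5-(hydroxymethyl)oxolan-2-yl becomes 4-hydroxy-5-(hydroxymethyl)oxolan-2-yl. For the measured compounds named here, no measured pair shows what this change does, so the estimate stays near compound 2 (340 nM). What is expected in this assay is a 1.2-fold higher number from compound 2 to compound 3 (0.07 log units; within the scatter) and thus no shift beyond the scatter. Compound 3 is expected to give about 400 nM (estimated range 170 nM to 950 nM).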

Compound 3, half-maximal inhibitory concentration: 20 nM
Estimate against measurement, compound 3: 20-fold (1.30 log units) above, outside the stated range (below it).
By their numbers in this assay, from the lowest: compound 3; then compounds 2 and 1 (each within the scatter of the next).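

In this assay the loss of this one hydroxy gives a 17-fold lower number from compound 2 to compound 3 (1.23 log units; beyond the scatter) and so shows that, on the shared core, 3,4-dihydroxy-5-(hydroxymethyl)oxolan-2-yl and 4-hydroxy-5-(hydroxymethyl)oxolan-2-yl are far from interchangeable. Compounds 1 and 2 differ in more than one place and lie within the scatter of each other, so they gave no sign that a single hydroxy on a saturated ring carbon, next to the ring atom that bears a large group, could matter this much. Nothing measured here explains the size of this step.

The compounds shown compare only hydroxy and hydrogen at this position, so it remains open whether a fluorine atom, a methoxy group or an amine there would behave more like the one or the other. From the compounds shown here alone, it is also open whether removing the remaining ring hydroxy would move the number further.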